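Bromo for fluoro in a series that sits at the limit

A few compounds are considered here, and "the series" means these few. Any claim that something is new, unique, unknown or untested is made for them only; others in the source may bear on it.

Compound 3 `O=C(CNc1ccc(F)cc1)N[C@H]1CCOC1=O` is a lactam amide carrying a fluoro group on its aromatic ring. In a functional assay on DU-145 cells (Homo sapiens) for antiproliferative activity, read by MTT assay, with a stated time of 72 h (on this read-out higher numbers stand for weaker inhibition and lower numbers for stronger inhibition), compound 3 gives > 64000 nM, which is a limit of the assay and not a number. Its companions stand in the same place. Compound 1 `O=C(CNc1ccccc1)N[C@H]1CCOC1=O`, the parent without a ring substituent, gives > 64000 nM in this assay, again a limit. Compound 2 `Cc1cc(Cl)ccc1NCC(=O)N[C@H]1CCOC1=O`, which carries chloro and methyl groups on the ring, gives > 64000 nM in this assay, also a limit. Within the data shown here, the one step that joins two of these structures, a step that the two limits leave unreadable from compound 1 to compound 3, cannot be read in size, since the limit of > 64000 nM in this assay, at which 3 of the 3 values shown sit, holds both of its ends. Compound 3 therefore stands nowhere on a scale; it stands at the ceiling shared by every measured value.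

Compound 4 `O=C(CNc1ccc(Br)cc1)N[C@H]1CCOC1=O` differs from compound 3 by bromo in place of fluoro on an aromatic carbon. Among the measured compounds shown here, no measured step bears on this exchange of one halogen for another; the only step in the set is unreadable. Nothing in the data points to a shift beyond the scatter in either direction. The step of a number no higher from compound 3 to compound 4 (the limit leaves the size open) that the estimate for compound 4 means is expected to be none worth reading. Compound 4 is expected to give 64000 nM, between 25000 nM and 200000 nM, most likely reported once more as a limit.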

Compound 4, half-maximal inhibitory concentration: > 64000 nM
Compound 4: a limit, no number (the forecaster's own chance of this, stated with the estimate: 85%); the middle value sits exactly at the limit.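

Compound 4 stands with compound 1 and compound 3 at a limit and not at a number, so neither of its steps, from compound 3 or from compound 1, can be read in size: the limit of > 64000 nM in this assay, at which 4 of the 4 values shown sit.

The compounds shown leave open whether any group on the aromatic ring of the shared core changes the read-out at all.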